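From 4-fluorobenzyl to (pyridin-4-yl)methyl at the assay limit

This account rests on a few compounds, and the source may have more. Where it says the series, first, only, none or still open, it means among the compounds named here.

In a functional assay on cells (Platelet, Homo sapiens) for inhibition (a lower number here means a stronger inhibitor, a higher number a weaker inhibitor), three compounds have been measured, each value being a limit of the assay:
compound 1 `CCOC(=O)c1cccc(-c2n[nH]c3ccccc23)c1` gives > 10000 nM
compound 2 `CCOC(=O)c1ccc(-c2nn(Cc3ccc(F)cc3)c3ccccc23)cc1` gives > 10000 nM
compound 3 `CCOC(=O)c1cccc(-c2nn(Cc3ccccc3)c3ccccc23)c1` gives > 10000 nM

Compound 2 stands at > 10000 nM as a limit and not as a number. Compound 1 and compound 3 also stand only at limits. The change to compound 4 `CCOC(=O)c1ccc(-c2nn(Cc3ccncc3)c3ccccc23)cc1` is pyridin-4-yl in place of 4-fluorophenyl on a saturated chain carbon bound to an aromatic nitrogen and it can also be read as 4-fluorobenzyl to (pyridin-4-yl)methyl. Within the data shown here, the one measured step is a step that the two limits leave unreadable from compound 1 to compound 3 and it has no size to carry over. What the compounds share is the limit of > 10000 nM in this assay, at which 3 of the 3 values shown sit, and none of them yet gives a number. With compound 2 at > 10000 nM as a limit, no step beyond the scatter is expected in this assay and no direction can be argued. The estimated step is a step that the limit leaves unreadable from compound 2 to compound 4 and it is offered as an expectation only. For compound 4 the estimate is 12000 nM with an expected range from 4000 nM to 30000 nM and a limit of the assay is the likeliest expectation.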

Compound 4, half-maximal inhibitory concentration: > 10000 nM
Compound 4 gave a limit, no number; the forecaster's own chance of this, stated with the estimate: 75%; the middle value lies beyond the limit too.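

In this assay compound 4 gives > 10000 nM, which is a limit of the assay and not a number. Compound 2 also stands at a limit, so no step can be read between compound 2 and compound 4. The compounds shown leave open which change, if any, would give a measurable value in this assay.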